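Replacing a Branched Ester Chain with a Small Amide

The source may report more compounds than this note shows. Statements on the series, on what has been measured and on what is new or still open speak of the compounds shown alone.

Three diaryl-imidazole derivatives carry a flexible chain bearing an ester or amide. Compound 1, `CCOC(=O)CCCOc1ccc(-n2cnc(-c3ccccc3)c2-c2ccccc2)cc1`, is measured in an assay on H4 cells for inhibition of Fatty-acid amide hydrolase 1 (Homo sapiens) (a higher number here means a weaker inhibitor, a lower number a stronger inhibitor), at 64 nM. Compound 2, `CCOC(=O)CCCCCCn1c(CC)nc(-c2ccccc2)c1-c1ccccc1`, gives 11 nM in this assay. Compound 3, `CCOC(=O)CC(CCCCCn1c(C)nc(-c2ccccc2)c1-c1ccccc1)C(C)C`, returns only a limit in this assay, > 100000 nM, which is the upper limit of the measurement and not a number. This places compound 3 at the limit of > 100000 nM in this assay, at which 1 of the 3 values shown sits, far from the two compounds that gave numbers, while compounds 1 and 2 both show values that are low in comparison.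

Compound 4, `Cc1nc(-c2ccccc2)c(-c2ccccc2)n1CCCCCCC(=O)N(C)C`, is yet to be tested. It differs from compound 3 by (dimethylcarbamoyl)methyl in place of 1-((ethoxycarbonyl)methyl)-2-methylpropyl on a saturated chain carbon, five bonds along the chain from an aromatic nitrogen. The branched chain that carries the ester in compound 3 is replaced by a shorter unbranched chain ending in a dimethylamide, which brings compound 4 closer in shape to compound 2, whose chain is likewise unbranched and whose value of 11 nM is among the lowest shown.

Without a measured pair for this change, the expectation is a large step downward from compound 3 to compound 4, an at least 2500-fold lower number from compound 3 to compound 4 (3.39 log units; beyond the scatter), well beyond the scatter. Compound 4 is therefore estimated at 40 nM in this assay, within a range of 5 nM to 400 nM.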

Compound 4, half-maximal inhibitory concentration: 970 nM
Compound 4: middle estimate off by 24-fold (1.38 log units), on the low side; measured number above the stated range.
By their numbers in this assay, from the lowest: compound 2; then compound 1; then compound 4. At a limit, above all of these: compound 3.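

In this assay, going by these compounds alone, putting (dimethylcarbamoyl)methyl in place of 1-((ethoxycarbonyl)methyl)-2-methylpropyl on a saturated chain carbon, five bonds along the chain from an aromatic nitrogen, gives an at least 100-fold lower number from compound 3 to compound 4 (2.01 log units; beyond the scatter), the first step that can be read at this position. The size of that step is itself open-ended, as compound 3 gives a limit and not a number: the limit of > 100000 nM in this assay, at which 1 of the 4 values shown sits. The step still shows that the group at this position decides whether a number can be read at all, and that an ester at the chain end is not required for one, as compound 4, which carries a dimethylamide there, gives 970 nM.

The change removes the branch and exchanges the ester for the amide in a single step, so the compounds shown leave open which of the two accounts for it, and an unbranched chain ending in the ethyl ester would separate them. Also open, going by these compounds, is how a carboxylic acid, a primary amide or a longer chain ending in the dimethylamide would read at this position in this assay.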